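A few compounds are considered here, and "the series" means these few. Any claim that something is new, unique, unknown or untested is made for them only; others in the source may bear on it.

For the measured compounds named here, in a functional assay on QGY-7703 cells (Homo sapiens) for cytotoxicity, read by MTT assay, with a stated time of 24 h (on this read-out higher numbers stand for weaker inhibition and lower numbers for stronger inhibition), compound 1 `O=C1/C(=C/c2cccnc2)CN(S(=O)(=O)c2ccc([N+](=O)[O-])cc2)C/C1=C\c1ccccc1F` gives 5600 nM and holds the lowest number so far, against compound 2 `O=C1/C(=C/c2cccnc2)CN(S(=O)(=O)c2ccc(F)cc2)C/C1=C\c1ccccc1F` at 15300 nM and compound 3 `O=C1/C(=C/c2cccnc2)CN(S(=O)(=O)c2ccc(Cl)cc2)C/C1=C\c1ccccc1F` at 12100 nM in the same read-out. Compound 4 `O=C1/C(=C/c2cccnc2)CN(S(=O)(=O)c2ccc([N+](=O)[O-])cc2)C/C1=C\c1ccccc1C(F)(F)F` keeps the core of compound 1 and carries one change, trifluoromethyl in place of fluoro on an aromatic carbon (trifluoromethyl in place of fluoro on an aromatic carbon, ortho to a large group). Going by the values given here, no measured step touches this place. The modest steps (a 2.7-fold higher number from compound 1 to compound 2 (0.44 log units; beyond the scatter) and a 2.2-fold higher number from compound 1 to compound 3 (0.33 log units; beyond the scatter)) replace nitro elsewhere, and the step from fluoro to chloro (a 1.3-fold lower number from compound 2 to compound 3 (0.10 log units; within the scatter)) stays within the scatter. Those sizes give only weak guidance, and no step beyond the scatter is expected in this assay. The expected change is small (a 1.1-fold higher number from compound 1 to compound 4 (0.03 log units; within the scatter)) and its direction is uncertain. For compound 4 the estimated value is 6000 nM (expected range 2500 nM to 14000 nM).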

Compound 4, half-maximal inhibitory concentration: 7660 nM
Estimate against measurement, compound 4: 1.3-fold (0.11 log units) below; measured number inside the range.
By their numbers in this assay, from the lowest: compounds 1, 4, 3 and 2 (each within the scatter of the next, the first and the last beyond it).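

In this assay, for the compounds shown here, this is the first variation at the aromatic carbon carrying fluoro in compound 1, and trifluoromethyl in place of fluoro gives a 1.4-fold higher number from compound 1 to compound 4 (0.14 log units; within the scatter). With the nitro group kept, going from one heavy atom to four at this place therefore produces no step beyond the scatter. No measurement at hand explains this result.

As far as these compounds go, it remains open whether an amine or a carboxylic acid on this carbon would stay equally close to compound 1. Also open, from the compounds shown here alone, is whether trifluoromethyl behaves the same with fluoro or chloro in place of nitro.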